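From compound 3 to compound 4: leaving pyridin-3-yl behind

The compounds below may be only part of what the source reports. "The series", "measured", "known", "first", "only" and "open" are said of these compounds alone.

In an ADME assay (liver) for pharmacokinetics, with Liver microsome (Rattus norvegicus) as the target, read by LC-MS, using microsomes, tested at 2 uM (a higher number here means faster removal of the compound, a lower number slower removal), compound 3 `O=C(N[C@@H]1CCCC[C@H]1O)c1cnc(OCc2cccnc2)c(-c2ccc(Cl)cc2)c1` stands highest of the three measured compounds at 0.374 mL/min/kg, ahead of compound 2 `Cc1cc(COc2ncc(C(=O)N[C@@H]3CCCC[C@H]3O)cc2-c2ccc(Cl)cc2)on1` at 0.151 mL/min/kg and compound 1 `O=C(N[C@@H]1CCCC[C@H]1O)c1cnc(OCC2CC2)c(-c2ccc(Cl)cc2)c1` at 0.064 mL/min/kg. Compound 4 `CN(CC1CC1)c1ncc(C(=O)N[C@@H]2CCCC[C@H]2O)cc1-c1ccc(Cl)cc1` carries (cyclopropylmethyl)(methyl)amino in place of (pyridin-3-yl)methoxy on an aromatic carbon. Within the data shown here, two measured steps bear on this. Pyridin-3-yl replacing cyclopropyl gave a 5.8-fold higher number from compound 1 to compound 3 (0.77 log units; beyond the scatter), and pyridin-3-yl replacing 3-methyl-1,2-oxazol-5-yl gave a 2.5-fold higher number from compound 2 to compound 3 (0.39 log units; beyond the scatter). Among the measured compounds shown here, no measured step covers the exchange of the oxygen for a methyl-bearing nitrogen, so only part of the larger step is expected to reverse. The expected change is a 2.5-fold lower number from compound 3 to compound 4 (0.40 log units; beyond the scatter). For compound 4 the estimate is 0.15 mL/min/kg, with an expected range of 0.05 mL/min/kg to 0.45 mL/min/kg.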

Compound 4, clearance: 1.73 mL/min/kg
The estimate for compound 4 lay 12-fold (1.06 log units) below the measured number; the whole stated range lies below it.
By their numbers in this assay, from the lowest: compound 1; then compound 2; then compound 3; then compound 4.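

In this assay, among these compounds, the one pair that keeps the cyclopropylmethyl group and exchanges only the oxygen for a methyl-bearing nitrogen shows the largest step here (a 27-fold higher number from compound 1 to compound 4 (1.43 log units; beyond the scatter)), well beyond any step among the ether compounds. The amino group also stands above the other two ethers (an 11-fold higher number from compound 2 to compound 4 (1.06 log units; beyond the scatter); a 4.6-fold higher number from compound 3 to compound 4 (0.67 log units; beyond the scatter)), so at this aromatic carbon next to the ring nitrogen, the atom bound to the ring moved the number more than the group on the chain did. Nothing available explains this rise.

Still open, as far as these compounds go, is whether the rise follows the nitrogen or its methyl group, which a secondary amine carrying only cyclopropylmethyl would separate. From the compounds shown here alone, whether a (pyridin-3-yl)methylamino group would rise in the same way also remains unknown.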